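The source may hold more compounds than are shown below. What is called first, only, known or untested is meant among the compounds shown, and "the series" means these compounds.

Compound 1 `CC(C)N1CCn2nc(-c3ccc(Cl)cc3)cc2C1=O` gives 31000 nM in a functional assay on A549 cells (Homo sapiens) for inhibition, read by MTT assay, with a stated time of 48 h; a lower number here means a stronger inhibitor, a higher number a weaker inhibitor. Compound 2 `CC(C)N1CCn2nc(-c3ccccc3)cc2C1=O` marks (the limit of > 64000 nM in this assay, at which 1 of the 2 values shown sits). In this assay compound 2 gives > 64000 nM, which is a limit of the assay rather than a number. Among the measured compounds shown here, the only measured step, an at least 2.0-fold higher number from compound 1 to compound 2 (0.31 log units; beyond the scatter), changes the aromatic chloro and says nothing about the amide nitrogen. Compound 3 `O=C1c2cc(-c3ccccc3)nn2CCN1Cc1ccc(Cl)nc1` differs from compound 2 by (6-chloropyridin-3-yl)methyl in place of isopropyl on an amide-type nitrogen in a ring. For the measured compounds named here, no measured step bears on this change, so no direction can be drawn from the data. Compound 3 is therefore expected near 60000 nM, between 15000 nM and 200000 nM. That amounts to an estimated step of an at least 1.0-fold lower number from compound 2 to compound 3 (0.02 log units; that floor lies within the scatter).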

Compound 3, half-maximal inhibitory concentration: > 64000 nM
Compound 3: no number, only a limit; the forecaster's own chance of this, stated with the estimate: 55%; middle value at least 1.0-fold (0.02 log units) away from the limit.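

In this assay compound 3 gives > 64000 nM, a limit rather than a number. Among the compounds shown here, no step from compound 2 to compound 3 can be read, because both end at the same limit: the limit of > 64000 nM in this assay, at which 2 of the 3 values shown sit. Going by these compounds, whether (6-chloropyridin-3-yl)methyl in place of isopropyl changes the number at all stays open.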